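Cyclobutyl for sec-butyl on the ester oxygen

The source may hold more compounds than are shown below. What is called first, only, known or untested is meant among the compounds shown, and "the series" means these compounds.

Of the compounds shown here, three of one shared core have been measured in an assay on membranes from CHO cells for displacement of a labelled ligand from adenosine receptor A1 (Homo sapiens), read by scintillation counting, with a stated time of 60 min, tested at 1 uM; a lower number here means less inhibition, a higher number more inhibition at the concentration tested (going by the name of the read-out). Compound 1 `CC1=C(C(=O)OC(C)(C)C)C(c2ccsc2)NC(=O)N1` gives 15%, compound 2 `CC(=O)C1=C(C)NC(=O)NC1c1ccsc1` gives 9%, and compound 3 `CCC(C)OC(=O)C1=C(C)NC(=O)NC1c1ccsc1` gives 5%. Compound 3 stands at the bottom of the three numbers shown, yet its gap to the nearest, a number 4 percentage points lower from compound 2 to compound 3 (within the scatter), and to the furthest, a number 10 percentage points lower from compound 1 to compound 3 (within the scatter), both lie within the scatter, so the three compounds cannot be ranked against one another.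

Compound 4 `CC1=C(C(=O)OC2CCC2)C(c2ccsc2)NC(=O)N1` has not yet been measured. It differs from compound 3 in one place: cyclobutyl in place of sec-butyl on an oxygen next to a carbonyl group. The step that bears most directly on this change is the earlier one at the same oxygen, a number 10 percentage points lower from compound 1 to compound 3 (within the scatter), which stayed within the scatter; the step at the carbonyl carbon, a number 6 percentage points lower from compound 1 to compound 2 (within the scatter), likewise stayed within it. Every change tried so far at this end of the molecule has left the number in this assay where it was. Compound 4 is therefore expected to show a number 3 percentage points higher from compound 3 to compound 4 (within the scatter) in this assay, no step beyond the scatter in either direction. The estimate for compound 4 in this assay is 8%, with an expected range from 0% to 20%.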

Compound 4, a percentage reported as inhibition, at one concentration (the size of the read-out at that concentration, not a potency): 40%
Beside the measured number, compound 4's estimate is 32 percentage points below it; measured number above the stated range.
By their numbers in this assay, from the lowest: compounds 3, 2 and 1 (each within the scatter of the next); then compound 4.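

At the oxygen next to a carbonyl group, this assay now shows a change that moves the number beyond the scatter: the exchange of sec-butyl for cyclobutyl gives a number 35 percentage points higher from compound 3 to compound 4 (beyond the scatter) and so shows that this position is not silent, as compounds 1, 2 and 3 alone had suggested. The other two comparisons point the same way, with cyclobutyl in place of tert-butyl giving a number 25 percentage points higher from compound 1 to compound 4 (beyond the scatter) on the same oxygen and cyclobutyloxy in place of methyl on the carbonyl carbon giving a number 31 percentage points higher from compound 2 to compound 4 (beyond the scatter) in this series. Between sec-butyl and cyclobutyl the counts of heavy atoms, hydrogen-bond donors and hydrogen-bond acceptors stay the same and neither group carries a net charge, so the computed comparison leaves the four-membered ring as the difference that comes with this step.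

Nothing in the data available explains why the number rises with this ring. From the compounds shown here alone, whether the rise belongs to cyclobutyl alone or extends to cyclopropyl, cyclopentyl or an oxetane on this oxygen stays open, as does what a cyclobutyl amide would give at the same carbonyl carbon.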